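The source may report more compounds than this note shows. Statements on the series, on what has been measured and on what is new or still open speak of the compounds shown alone.

The measured compounds:

Compound 1, `CC(C)c1nc(-c2nnc(C3CCN(C4CCC4)CC3)o2)c2ccccn12`, gives 55%.
Compound 2, `CC(C)c1nc(-c2nnc(C3CCN(CC4CCC4)CC3)o2)c2ccccn12`, gives 63%.
Compound 3, `CC(C)c1nc(C(=O)NC[C@@H]2[C@H]3CN(CC4CCC4)C[C@@H]23)c2ccccn12`, gives 50%.

All three were tested in a functional assay on CHO cells for agonist activity at 5-hydroxytryptamine receptor 4 (Homo sapiens), read by a luciferase reporter and cAMP accumulation, with a stated time of 4 h; a higher number here means a larger maximal response, a lower number a smaller maximal response. Compound 1 and compound 2 share one core and differ in a single place: cyclobutyl in place of cyclobutylmethyl on an amine nitrogen in a ring. That change made a step of a number 8 percentage points lower from compound 2 to compound 1 (within the scatter), so the two values lie within the usual scatter of each other and no order between them can be claimed. Compound 3 carries a different core; the difference between the two cores is not broken down here. Its value in this assay is the lowest of the three numbers, within the scatter of compound 1 but beyond the scatter of compound 2.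

Compound 4, `CC(C)c1nc(C(=O)NC[C@@H]2[C@H]3CN(C4CCC4)C[C@@H]23)c2ccccn12`, has not yet been measured. It is related to compound 3 by the same kind of change that relates compound 1 to compound 2: cyclobutyl in place of cyclobutylmethyl on an amine nitrogen in a ring. The surroundings of the place differ, however: in compound 3 the amine nitrogen sits in a five-membered non-aromatic ring with one nitrogen, part of a fused or bridged system of two rings, with two ring bonds from two ring atoms that each bear a fused ring, whereas in compound 2 it sits in a six-membered non-aromatic ring with one nitrogen, with three ring bonds from the ring atom that bears a large group.

Within the data shown here, on the basis of the one earlier instance, the step from compound 3 to compound 4 in this assay is expected to be small, about a number 5 percentage points lower from compound 3 to compound 4 (within the scatter), because the matching step was a number 8 percentage points lower from compound 2 to compound 1 (within the scatter). For compound 4 an expected value of 45% is estimated, with a range from 30% to 60%.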

Compound 4, largest response reached (Emax), in percent of the reference or control that the assay uses: 59%
The estimate for compound 4 lay 14 percentage points below the measured number; the measured number falls inside the stated range.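

In this assay, cyclobutyl in place of cyclobutylmethyl on the amine nitrogen of the five-membered ring gave a number 9 percentage points higher from compound 3 to compound 4 (within the scatter), so no order between these two compounds can be claimed. Set beside the same change on the other core, this step shows that the change did not carry over as a fixed amount, since the two steps run in opposite directions and the gap between them exceeds the scatter: the same change on two cores in this assay, a number 8 percentage points lower (within the scatter) from compound 2 to compound 1 and a number 9 percentage points higher (within the scatter) from compound 3 to compound 4, 17 percentage points apart, beyond the scatter of two such steps. Among these compounds, each step on its own remains within the scatter and each core supplies only one pair, so the result does not show that the change raises the maximal response on one core and lowers it on the other, and it does not show which feature of the cores lies behind the gap.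

The compounds shown leave open whether the same gap would appear with other groups on that amine nitrogen, such as a methyl, an isopropyl, a cyclopropylmethyl or a cyclopentyl. They also leave open whether the swap between cyclobutylmethyl and cyclobutyl would behave on a third core as it did on either of these two.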